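The source may report more compounds than this note shows. Statements on the series, on what has been measured and on what is new or still open speak of the compounds shown alone.

Measured in a functional assay on the whole organism (heart left ventricle) with Canis familiaris (Canis lupus familiaris) as the target; on this read-out higher numbers stand for an effect only at larger amounts of compound and lower numbers for an effect already at smaller amounts:
- compound 1 `COc1cc(OS(C)(=O)=O)ccc1-c1nc2cc[nH]cc-2n1`: 0.002 mg/kg
- compound 2 `COc1cc(C(N)=O)ccc1-c1cn2ccncc2n1`: 0.02 mg/kg
- compound 3 `COc1cc(C(N)=O)ccc1-c1cn2ccnc(OC)c2n1`: 0.06 mg/kg

Compound 3 has the highest number of the three. Compound 4 `COc1cc(OS(C)(=O)=O)ccc1-c1cn2ccnc(OC)c2n1` carries (methylsulfonyl)oxy in place of carbamoyl on an aromatic carbon. Within the data shown here, the one measured step, a 3.0-fold higher number from compound 2 to compound 3 (0.48 log units; beyond the scatter), concerns methoxy in place of hydrogen, which compound 4 keeps, so it says nothing direct about this exchange. Among the measured compounds shown here, no measured pair isolates the exchange. For the measured compounds named here, the only guide is compound 1, which has (methylsulfonyl)oxy on a different core and stands at 0.002 mg/kg. A lower number is therefore expected, but with wide uncertainty. The expected change is a 3.0-fold lower number from compound 3 to compound 4 (0.48 log units; beyond the scatter). For compound 4 the estimated value is 0.02 mg/kg, with an expected range of 0.005 mg/kg to 0.08 mg/kg.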

Compound 4, dose for half-maximal effect: 0.07 mg/kg
The estimate for compound 4 lay 3.5-fold (0.54 log units) below the measured number, and the stated range covers the measured number.
By their numbers in this assay, from the lowest: compound 1; then compound 2; then compounds 3 and 4 (each within the scatter of the next).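

In this assay, (methylsulfonyl)oxy in place of carbamoyl gives a 1.2-fold higher number from compound 3 to compound 4 (0.07 log units; within the scatter) on the core that carries the methoxy group. At this place, para to a large group, the hydrogen-bond donor of carbamoyl can thus be lost and heavy atoms added with no change beyond the scatter. No measurement bears on why the number holds.

On these data alone, whether an amine, a carboxylic acid or a sulfonamide at this place would hold the number stays open. Also open, as far as these compounds go, is whether the same exchange would read alike on the core of compound 1.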